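Ethyl in Place of tert-Butyl on the Amine

The source may hold more compounds than are shown below. What is called first, only, known or untested is meant among the compounds shown, and "the series" means these compounds.

Measured compounds:
- Compound 1, `CCN(CC)Cc1cc(Nc2nc3ccccc3n2Cc2ccc(C#N)cc2)ccc1O`: in an ADME assay on CHO cells (Cricetulus griseus) for inhibition, read by MTT assay (on this read-out lower numbers stand for stronger inhibition and higher numbers for weaker inhibition), compound 1 gives > 50000 nM, which is a limit of the assay and not a number.
- Compound 2, `Cc1cc(CNC(C)(C)C)c(O)c(Nc2nc3cc(F)c(F)cc3n2Cc2ccc(C(F)(F)F)cc2)c1`: compound 2 gives 10000 nM.
- Compound 3, `Cc1cc(CNC(C)(C)C)c(O)c(Nc2nc3cc(F)c(F)cc3[nH]2)c1`: compound 3 gives 16700 nM.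

Compound 1 sits at the limit of > 50000 nM in this assay, at which 1 of the 3 values shown sits. Of the two actual numbers, compound 2 stands with compound 3 as its nearest neighbour, and the step of a 1.7-fold higher number from compound 2 to compound 3 (0.22 log units; within the scatter), hydrogen in place of 4-(trifluoromethyl)benzyl on an aromatic nitrogen, lies within the scatter, so the two are not told apart.

Compound 4, `CCNCc1cc(C)cc(Nc2nc3cc(F)c(F)cc3n2Cc2ccc(C(F)(F)F)cc2)c1O`, is not yet measured. It differs from compound 2 by ethyl in place of tert-butyl on an amine nitrogen. No measured step touches this amine nitrogen: the only step shown, a 1.7-fold higher number from compound 2 to compound 3 (0.22 log units; within the scatter), concerns the aromatic nitrogen and stays within the scatter. With nothing measured at the changed place, the expectation for compound 4 is a step no larger than the scatter, which is what the estimated step of a 1.2-fold higher number from compound 2 to compound 4 (0.08 log units; within the scatter) means. Compound 4 is therefore estimated at 12000 nM, with a range from 4000 nM to 35000 nM.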

Compound 4, half-maximal inhibitory concentration in the CHO assay: 2040 nM
Compound 4: middle estimate off by 5.9-fold (0.77 log units), on the high side; the whole stated range lies above it.
By their numbers in the CHO assay, from the lowest: compound 4; then compounds 2 and 3 (each within the scatter of the next). At a limit, above all of these: compound 1.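

Compounds 1 to 3 left the amine nitrogen untouched, and this pair shows that the group there counts: in the CHO assay, ethyl in place of tert-butyl gives a 4.9-fold lower number from compound 2 to compound 4 (0.69 log units; beyond the scatter), a clear change from a small edit. In a physicochemical assay for solubility, read by HPLC, measured as kinetic solubility, with a stated time of 24 h, at pH 6.5 (a higher number here means a more soluble compound, a lower number a less soluble compound), compound 2 gives < 5000 nM, which is a limit of the assay and not a number. In the physicochemical assay compound 4 gives 16000 nM, and the same change reads as an at least 3.2-fold higher number from compound 2 to compound 4 (0.50 log units; beyond the scatter), so one edit moves both read-outs beyond the scatter.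

Going by these compounds, with only these two groups on this nitrogen, it stays open how a methyl, a longer chain such as propyl, or a cyclopropyl ring would read in either assay, and whether the two read-outs would always move together. Nothing given here explains either step.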